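Fluoro to Methoxy on the Aryl Ring of Compound 2

A few compounds are considered here, and "the series" means these few. Any claim that something is new, unique, unknown or untested is made for them only; others in the source may bear on it.

In an assay for displacement of a labelled ligand from DNA repair protein REV1 (Homo sapiens), read by fluorescence polarization, with a stated time of 1 h (on this read-out higher numbers stand for weaker inhibition and lower numbers for stronger inhibition), compound 2 `CCc1ccc(NC(=O)CN2CCN(c3ccc(F)cc3)CC2)cc1` gives 2500 nM. Compound 1 `CC(=O)N1CCC(C(=O)Nc2sc3c(c2C(=O)NC2CC2)CCC(C)C3)CC1` gives 2500 nM, level with compound 2 within the scatter. Compound 3 `N#Cc1ccc(NC(=O)CN2CCN(c3ccc(F)cc3)CC2)cc1` reaches only a limit of the assay, > 50000 nM. That limit is the limit of > 50000 nM in this assay, at which 1 of the 3 values shown sits. The step of an at least 20-fold higher number from compound 2 to compound 3 (1.30 log units; beyond the scatter) comes from cyano in place of ethyl on an aromatic carbon. Compound 4 `CCc1ccc(NC(=O)CN2CCN(c3ccc(OC)cc3)CC2)cc1` differs from compound 2 by methoxy in place of fluoro on an aromatic carbon. Going by the values given here, no measured step touches the fluoro of compound 2, and the only measured step alters a different group, so it does not bear directly on this change. Compound 4 is therefore expected to stay near compound 2, with the step of no change at the digits printed from compound 2 to compound 4 (within the scatter) within the scatter. The estimate for compound 4 is 2500 nM, between 1000 nM and 8000 nM.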

Compound 4, half-maximal inhibitory concentration: 5500 nM
Estimate against measurement, compound 4: 2.2-fold (0.34 log units) below; measured number inside the range.
By their numbers in this assay, from the lowest: compounds 1 and 2 (each within the scatter of the next); then compound 4. At a limit, above all of these: compound 3.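

The fluoro of compound 2, para to a large group, was untouched by the earlier step, and this position now proves sensitive: methoxy in place of fluoro gives a 2.2-fold higher number from compound 2 to compound 4 (0.34 log units; beyond the scatter). That is weaker inhibition in this assay, though compound 4 still gives a measured value of 5500 nM rather than a limit of the assay. Nothing shown here accounts for the direction of this step.

Going by these compounds alone, with only two groups seen at this position, it remains open whether an amine, a hydroxyl or a longer chain such as ethoxy would raise the number further or lower it.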